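The compounds below may be only part of what the source reports. "The series", "measured", "known", "first", "only" and "open" are said of these compounds alone.

Three compounds sharing the core of compound 1 `CC1CCN(C2CCN(S(=O)(=O)c3cn(C)cn3)CC2)CC1` have been tested in a functional assay on DLD-1 cells (Homo sapiens) for antiproliferative activity, read by CellTiter-Glo, with a stated time of 72 h; a lower number here means a stronger inhibitor, a higher number a weaker inhibitor. For compound 1 this assay reports only a limit, > 5000 nM, so no exact number is known (the limit of > 5000 nM in this assay, at which 1 of the 3 values shown sits). Compound 2 `CC1CCN(C2CCN(S(=O)(=O)c3ccc(OCc4ccccc4)cc3)CC2)CC1` gives 385 nM in this assay, and compound 3 `CC1CCN(C2CCN(S(=O)(=O)c3cccc(-c4ccc(Cl)cc4)c3)CC2)CC1` gives 15 nM. The unmeasured compound 4 `CC1CCN(C2CCN(S(=O)(=O)c3cccnc3F)CC2)CC1` differs from compound 1 in a single place: 2-fluoropyridin-3-yl in place of 1-methyl-1H-imidazol-4-yl on a sulfonyl sulfur. Within the data shown here, no step between measured compounds matches this exchange of one small aromatic ring for another. The step from compound 1 to compound 4 is therefore expected to be modest, an at least 1.2-fold lower number from compound 1 to compound 4 (0.09 log units; that floor lies within the scatter), with compound 4 likely remaining a weak inhibitor. Compound 4 is estimated at 4000 nM, with a range from 1000 nM to 20000 nM, and a real chance that this assay again reports only a limit.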

Compound 4, half-maximal inhibitory concentration: > 5000 nM
Compound 4: only a limit was reported (the forecaster's own chance of this, stated with the estimate: 55%); at least 1.2-fold (0.09 log units) between middle value and limit.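

Compound 1 and compound 4 are each reported only as a limit, so no step can be read between them: the limit of > 5000 nM in this assay, at which 2 of the 4 values shown sit.

As far as these compounds go, what stays open is whether 2-fluoropyridin-3-yl in place of 1-methyl-1H-imidazol-4-yl changes activity at all, and by how much.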